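Methyl to hydrogen on the aromatic ring, two cases

A few compounds are considered here, and "the series" means these few. Any claim that something is new, unique, unknown or untested is made for them only; others in the source may bear on it.

In a functional assay on A-431 cells (Homo sapiens) for cytotoxicity, read by MTT assay, with a stated time of 72 h, tested at 3 uM (on this read-out higher numbers stand for more inhibition of growth at the one concentration tested and lower numbers for less inhibition of growth), compound 1 `N/C(=N\NC(=S)N1CCCCCC1)c1ccccn1` gives 50.3%. Compound 3 `Cc1ccnc(/C(N)=N/NC(=S)N2CCCCCC2)c1` gives 36.1%, and compound 2 `Cc1ccnc(/C(N)=N/NC(=S)N2CCN(c3ccccn3)CC2)c1` gives 34.7%; the values of compound 2 and compound 3 sit within the scatter of each other, while compound 1 stands beyond the scatter above both. The change hydrogen in place of methyl on an aromatic carbon produced a number 14.2 percentage points higher from compound 3 to compound 1 (beyond the scatter), a modest gain. Compound 4 `N/C(=N\NC(=S)N1CCN(c2ccccn2)CC1)c1ccccn1` carries the same change on the core of compound 2, (hydrogen in place of methyl on an aromatic carbon), with the place described in the same words. How the cores of compound 2 and compound 3 differ is not broken down here. For compound 4 a step of about a number 13.3 percentage points higher from compound 2 to compound 4 (beyond the scatter) is expected, because the same change gave a number 14.2 percentage points higher from compound 3 to compound 1 (beyond the scatter). Compound 4 is therefore estimated at 48%, between 36% and 60%.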

Compound 4, percent growth inhibition at one concentration: 45.8%
For compound 4 the middle estimate is 2.2 percentage points above the measured one; measured number inside the range.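

Exchanging 4-methylpyridin-2-yl for pyridin-2-yl in this assay gives a number 11.1 percentage points higher from compound 2 to compound 4 (beyond the scatter). The step carries from one core to the other with no difference beyond the scatter: the same change on two cores in this assay, a number 14.2 percentage points higher (beyond the scatter) from compound 3 to compound 1 and a number 11.1 percentage points higher (beyond the scatter) from compound 2 to compound 4, 3.1 percentage points apart, within the scatter of two such steps. This agreement rests on two cores, one cell line and a single concentration, so it supports transfer between these cores only and shows neither why the step arises nor whether it would hold on a third core.

The compounds shown leave open what other groups at this place on the pyridine ring would give, such as an ethyl, a methoxy, a chlorine or an amine. They also leave open whether such groups would follow the same course on both cores.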